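Isopropyl for 4-chlorophenyl on the amide-type nitrogen

The source may hold more compounds than are shown below. What is called first, only, known or untested is meant among the compounds shown, and "the series" means these compounds.

Compound 1 (`COc1cccc(N2C(=O)COc3ccc(-c4cnc(OC)c(NS(=O)(=O)c5ccc(F)cc5)c4)cc32)c1`) reads > 40000 nM in a functional assay on HepG2 cells (Homo sapiens) for antiproliferative activity, read by MTT assay, with a stated time of 72 h (on this read-out lower numbers stand for stronger inhibition and higher numbers for weaker inhibition), and that is a limit of the assay, not a number. Compound 2 (`COc1ncc(-c2ccc3c(c2)N(c2ccc(F)cc2)C(=O)CO3)cc1NS(=O)(=O)c1ccc(F)cc1`) gives 36400 nM as a measured number. Among the compounds with values here, compound 3 (`COc1ncc(-c2ccc3c(c2)N(c2ccc(Cl)cc2)C(=O)CO3)cc1NS(=O)(=O)c1ccc(F)cc1`) gives 17900 nM and holds the lower of the two measured numbers so far.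

The change to compound 4 (`COc1ncc(-c2ccc3c(c2)N(C(C)C)C(=O)CO3)cc1NS(=O)(=O)c1ccc(F)cc1`) is isopropyl in place of 4-chlorophenyl on an amide-type nitrogen in a ring and the six-membered aromatic ring leaves that nitrogen with it.

Within the data shown here, three measured steps bear on this: an at least 1.0-fold lower number from compound 1 to compound 2 (0.04 log units; that floor lies within the scatter) for 4-fluorophenyl in place of 3-methoxyphenyl, an at least 2.2-fold lower number from compound 1 to compound 3 (0.34 log units; beyond the scatter) for 4-chlorophenyl in place of 3-methoxyphenyl, and a 2.0-fold lower number from compound 2 to compound 3 (0.31 log units; beyond the scatter) for chloro in place of fluoro. All three exchange one substituted phenyl for another. None of them shows a nitrogen carrying a group without a ring, so they give a scale of size and no direction.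

The expected step is a 1.1-fold higher number from compound 3 to compound 4 (0.05 log units; within the scatter) and no shift beyond the scatter is expected, with a wide margin on either side. For compound 4 the estimate in this assay is 20000 nM with an expected span from 4000 nM to 40000 nM as a working range.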

Compound 4, half-maximal inhibitory concentration: 37200 nM
The estimate for compound 4 lay 1.9-fold (0.27 log units) below the measured number; low and high end bracket the measured number.
By their numbers in this assay, from the lowest: compound 3; then compounds 2 and 4 (each within the scatter of the next). At a limit, above all of these: compound 1.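

In this assay, isopropyl, which has no ring, in place of 4-fluorophenyl on the amide-type nitrogen gives a 1.0-fold higher number from compound 2 to compound 4 (0.01 log units; within the scatter). The same exchange against 4-chlorophenyl gives a 2.1-fold higher number from compound 3 to compound 4 (0.32 log units; beyond the scatter), of similar size to the chloro for fluoro step, a 2.0-fold lower number from compound 2 to compound 3 (0.31 log units; beyond the scatter), so among the groups with measured numbers only the 4-chlorophenyl of compound 3 stands apart, and only modestly. Isopropyl in place of 3-methoxyphenyl gives an at least 1.0-fold lower number from compound 1 to compound 4 (0.03 log units; that floor lies within the scatter), and this floor is all that can be read of that step. Compound 1 carries a limit of the assay and not a number: the limit of > 40000 nM in this assay, at which 1 of the 4 values shown sits.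

The measured numbers for compound 2, compound 3 and compound 4 all remain high, so the compounds shown do not settle whether any group on this nitrogen can bring a large gain in this assay. Still open, as far as these compounds go, is what the amide hydrogen, a methyl group, a longer chain ending in an amine or a carboxylic acid would do at this position, and whether larger halogens on the phenyl ring would extend the step seen with chloro.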